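Working notes: thiophen-2-yl in place of furan-2-yl

This account rests on a few compounds, and the source may have more. Where it says the series, first, only, none or still open, it means among the compounds named here.

Measured so far in a functional assay on KB cells (Homo sapiens) for antiproliferative activity; a higher number here means a weaker inhibitor, a lower number a stronger inhibitor:
- compound 1, `COc1ccc(C(c2ccc3cccnc3c2O)c2ccc3cccnc3c2O)cc1`; compound 1 gives < 0.3 ug/mL, which is a limit of the assay.
- compound 2, `Oc1c(C(c2ccco2)c2ccc3cccnc3c2O)ccc2cccnc12`; compound 2 gives < 0.3 ug/mL, again a limit of the assay.
- compound 3, `COc1ccc(C(c2ccc(C(C)C)cc(=O)c2O)c2oc(CO)cc(=O)c2O)cc1`; compound 3 gives 0.5 ug/mL.

Compound 2 thus stands at the limit, and so do two of the three values shown (the limit of < 0.3 ug/mL in this assay, at which 2 of the 3 values shown sit). For the measured compounds named here, the one step measured at the saturated chain carbon, a step that the two limits leave unreadable from compound 1 to compound 2, runs between two limits and its size cannot be read.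

The next compound, compound 4, `Oc1c(C(c2cccs2)c2ccc3cccnc3c2O)ccc2cccnc12`, differs from compound 2 by thiophen-2-yl in place of furan-2-yl on a saturated chain carbon bound to two aromatic carbons. Going by the values given here, no measured step exchanges furan-2-yl for thiophen-2-yl; the only step at this place is the unreadable one from compound 1 to compound 2, and compound 3 carries a different core, so it gives no bearing on this exchange. No step beyond the scatter is therefore expected in this assay in either direction, and the step that the limit leaves unreadable from compound 2 to compound 4 is estimated as essentially flat. Compound 4 is expected at 0.2 ug/mL, within 0.05 ug/mL to 0.6 ug/mL, most likely reported again as a limit rather than a number.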

Compound 4, half-maximal inhibitory concentration: < 0.3 ug/mL
Compound 4: no number, only a limit (the forecaster's own chance of this, stated with the estimate: 65%); the middle value lies beyond the limit too.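

Compound 4 gives < 0.3 ug/mL and this is a limit of the assay, not a number. The steps among compound 1, compound 2 and compound 4 therefore cannot be read: the limit of < 0.3 ug/mL in this assay, at which 3 of the 4 values shown sit.

The compounds shown leave open how far apart these three lie, and whether thiophen-2-yl, furan-2-yl and 4-methoxyphenyl differ at all on the saturated chain carbon.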